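The compounds below may be only part of what the source reports. "The series", "measured", "known", "first", "only" and "open" are said of these compounds alone.

In a functional assay on G-361 cells (Homo sapiens) for cytotoxicity, read by fluorescence, with a stated time of 72 h (on this read-out higher numbers stand for weaker inhibition and lower numbers for stronger inhibition), three compounds sharing one core have been measured. Compound 1 `CC(C)c1n[nH]c2c(NCc3ccc(-c4ccccn4)cc3)nc(S(C)(=O)=O)nc12` carries methylsulfonyl on an aromatic carbon and gives 793 nM as its value. Compound 2 `CC(C)c1n[nH]c2c(NCc3ccc(-c4ccccn4)cc3)nc(NCCO)nc12` carries (2-hydroxyethyl)amino there and gives 39 nM as its value. Compound 3 `CC(C)c1n[nH]c2c(NCc3ccc(-c4ccccn4)cc3)nc(NCCN)nc12` carries (2-aminoethyl)amino and gives 230 nM as its value, the middle of the three numbers. Compound 4 `CC(C)c1n[nH]c2c(NCc3ccc(-c4ccccn4)cc3)nc(N3CCNCC3)nc12` has piperazin-1-yl in place of (2-aminoethyl)amino on that aromatic carbon (piperazin-1-yl in place of (2-aminoethyl)amino on an aromatic carbon). Three measured steps at this carbon bear on the change. The step of a 20-fold lower number from compound 1 to compound 2 (1.31 log units; beyond the scatter) is large, while a 3.4-fold lower number from compound 1 to compound 3 (0.54 log units; beyond the scatter) and a 5.9-fold higher number from compound 2 to compound 3 (0.77 log units; beyond the scatter) are modest. For the measured compounds named here, the last of these, which starts and ends on amino side chains, is the closest guide, although no measured compound has a ring at this carbon. The data therefore give no firm direction, and no step beyond the scatter is expected. In this assay the expected step is a 1.5-fold lower number from compound 3 to compound 4 (0.19 log units; within the scatter) on this reasoning. For compound 4 the estimate is 150 nM with an expected range from 50 nM to 450 nM in all.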

Compound 4, half-maximal inhibitory concentration: 64 nM
For compound 4 the middle estimate is 2.3-fold (0.37 log units) above the measured one; the range from low to high includes it.
By their numbers in this assay, from the lowest: compounds 2 and 4 (each within the scatter of the next); then compound 3; then compound 1.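

In this assay, for the compounds shown here, piperazin-1-yl in place of (2-aminoethyl)amino gives a 3.6-fold lower number from compound 3 to compound 4 (0.56 log units; beyond the scatter) and shows that this aromatic carbon, between two ring nitrogen atoms, tolerates a six-membered non-aromatic ring, which no earlier compound carried there. With a 12-fold lower number from compound 1 to compound 4 (1.09 log units; beyond the scatter) and a 1.6-fold higher number from compound 2 to compound 4 (0.22 log units; within the scatter) as the other two steps, the ring joins (2-hydroxyethyl)amino as a second replacement for methylsulfonyl that lies well clear of it, and the two replacements cannot be told apart in this assay. Nothing measured here explains why the ring and the open (2-aminoethyl)amino chain differ.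

Going by these compounds, it remains open whether the second ring nitrogen of piperazin-1-yl matters, which morpholin-4-yl or piperidin-1-yl at this carbon would test. Also open, on these data alone, is how a longer chain, such as (3-hydroxypropyl)amino, would compare with (2-hydroxyethyl)amino.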